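Swapping the aryl group on the triazole: compound 4

This account rests on a few compounds, and the source may have more. Where it says the series, first, only, none or still open, it means among the compounds named here.

Compound 1, `CCOc1ccc(-n2nncc2CN2C(=O)C3(C(C#N)=C(N)Oc4c(N)cc5nc6ccccc6nc5c43)c3ccccc32)cc1`, reaches in an ADME assay on HUVEC cells (Homo sapiens) for antiproliferative activity, read by MTT assay, with a stated time of 48 h (on this read-out higher numbers stand for weaker inhibition and lower numbers for stronger inhibition), only the limit > 50000 nM. Compound 2, `N#CC1=C(N)Oc2c(N)cc3nc4ccccc4nc3c2C12C(=O)N(Cc1cnnn1-c1c(F)cccc1F)c1ccccc12`, also stops at the limit > 50000 nM in this assay. Compound 3, `N#CC1=C(N)Oc2c(N)cc3nc4ccccc4nc3c2C12C(=O)N(Cc1cnnn1-c1ccc(Cl)cc1Cl)c1ccccc12`, likewise gives the limit > 50000 nM in this assay.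

Compound 3 thus stands where every measured compound stands: at the limit, with no number beneath it (the limit of > 50000 nM in this assay, at which 3 of the 3 values shown sit). Compound 4, `N#CC1=C(N)Oc2c(N)cc3nc4ccccc4nc3c2C12C(=O)N(Cc1cnnn1-c1ccc([N+](=O)[O-])cc1[N+](=O)[O-])c1ccccc12`, differs from compound 3 by 2,4-dinitrophenyl in place of 2,4-dichlorophenyl on an aromatic nitrogen. The three measured swaps on the same aromatic nitrogen are all unreadable: a step that the two limits leave unreadable from compound 1 to compound 2, a step that the two limits leave unreadable from compound 1 to compound 3 and a step that the two limits leave unreadable from compound 2 to compound 3. No readable step is therefore expected in this assay for the move from the dichloro to the dinitro ring. Compound 4 is expected to sit again at the limit, estimated as 70000 nM, between 25000 nM and 200000 nM. The expected step is a step that the limit leaves unreadable from compound 3 to compound 4.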

Compound 4, half-maximal inhibitory concentration: > 50000 nM
Compound 4 ended at the assay's limit; the forecaster's own chance of this, stated with the estimate: 85%; the middle value is on the limit's open side.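

Compound 4, like compound 1, compound 2 and compound 3, gives only a limit, so none of the steps between them can be read: the limit of > 50000 nM in this assay, at which 4 of the 4 values shown sit. The compounds shown leave open how strongly each inhibits in this assay and whether the aryl group on the aromatic nitrogen matters.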